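Replacing one phenyl group on the shared core

The source may hold more compounds than are shown below. What is called first, only, known or untested is meant among the compounds shown, and "the series" means these compounds.

Of the compounds shown here, two have been measured so far in a functional assay on U-87MG ATCC cells for antiproliferative activity against U-87 MG (Homo sapiens), read by spectrophotometry, with a stated time of 2 days; a higher number here means a weaker inhibitor of growth, a lower number a stronger inhibitor of growth. Compound 1 (`COc1ccc(Nc2ncc(C(F)(F)F)c(N3Cc4cccc(N(C)S(C)(=O)=O)c4C3)n2)cc1C(F)(F)F`) gives 29400 nM, and compound 2 (`CC(=O)N1CCN(c2ccc(Nc3ncc(C(F)(F)F)c(N4Cc5cccc(N(C)S(C)(=O)=O)c5C4)n3)cc2)CC1`) gives 22100 nM. These two values lie within the scatter of each other, so compound 1 stands level with compound 2 on the numbers available. Compound 3 (`Cc1ccc(Nc2ncc(C(F)(F)F)c(N3Cc4cccc(N(C)S(C)(=O)=O)c4C3)n2)cc1C`) has not yet been measured. It keeps the core of compound 1 but carries 3,4-dimethylphenyl in place of 4-methoxy-3-(trifluoromethyl)phenyl on a nitrogen on an aromatic ring. Going by the values given here, no measured pair shows what this change does, so no firm direction can be given, and no step beyond the scatter is expected in this assay. The expected step is a 1.3-fold lower number from compound 1 to compound 3 (0.13 log units; within the scatter). For compound 3 the estimated value is 22000 nM, with an expected range from 9000 nM to 50000 nM.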

Compound 3, concentration for 50% growth inhibition: > 30000 nM
Compound 3 gave a limit, no number (the forecaster's own chance of this, stated with the estimate: 15%); at least 1.3-fold (0.13 log units) between middle value and limit.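

In this assay compound 3 gives > 30000 nM, which is a limit of the assay and not a number. Going by these compounds, the change therefore reads only as a floor, an at least 1.0-fold higher number from compound 1 to compound 3 (0.00 log units; that floor lies within the scatter), and the true size of the step stays unknown: the limit of > 30000 nM in this assay, at which 1 of the 3 values shown sits. What it adds is that on this nitrogen, 3,4-dimethylphenyl brings no measurable gain in growth inhibition over 4-methoxy-3-(trifluoromethyl)phenyl, though whether it costs any activity cannot be told.

Since the methoxy and trifluoromethyl groups leave together, the compounds shown do not separate what either one contributes. They also leave open whether a different group on this phenyl ring, such as a primary amine or a carboxylic acid, would give a clearly lower number.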